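Swapping the large amide group for methyl

The source may report more compounds than this note shows. Statements on the series, on what has been measured and on what is new or still open speak of the compounds shown alone.

Compound 1 `CNC(=O)c1cc(C(=O)N[C@H]2[C@@H]3C[C@H](O)C[C@@H]32)cc2c1OC[C@@]2(C)c1ccccc1`: 3.7
Compound 2 `CNC(=O)c1cc(C(=O)NC)c2c(c1)[C@H](c1ccccc1)CO2`: 3.2

Both numbers come from a physicochemical assay for lipophilicity, at pH 7.4; on this read-out higher numbers stand for higher lipophilicity and lower numbers for lower lipophilicity. Compound 1 is the higher of the two, and compound 2 lies lower by more than the scatter. Compound 3 `CNC(=O)c1cc(C(=O)NC)c2c(c1)[C@](C)(c1ccccc1)CO2` has not yet been measured. The structural change from compound 1 to compound 3 is one carbon atom in place of a group of 7 heavy atoms (6 carbon, 1 oxygen; one three-membered non-aromatic ring of carbon only, one five-membered non-aromatic ring of carbon only), on an amide-type nitrogen.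

Among the compounds with values here, no measured pair isolates this change, so any forecast is loose. Within the data shown here, compound 2, at 3.2, also carries a methyl on an amide-type nitrogen and is the only measured guide. A small fall in this assay is expected, probably not beyond the scatter. The expected step is a number 0.20 log units lower from compound 1 to compound 3 (within the scatter). For compound 3 the estimate is 3.5, with an expected range from 3.1 to 3.9.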

Compound 3, distribution coefficient: 3.4
Estimate against measurement, compound 3: 0.10 log units above, within the range that was stated.
By their numbers in this assay, from the lowest: compounds 2, 3 and 1 (each within the scatter of the next, the first and the last beyond it).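

In this assay, replacing the group of 7 heavy atoms on the amide-type nitrogen with methyl gives a number 0.30 log units lower from compound 1 to compound 3 (within the scatter), so compound 1 and compound 3 cannot be told apart on this read-out. That holds even though the change removes both non-aromatic rings and all 4 defined stereocentres of that group. Compound 2 differs from compound 1 in more than one place and could not isolate this position, whereas compound 3 ties the comparison to this one change. Nothing measured here offers a reason for the size of this step.

Within the data shown here, only two groups on this amide-type nitrogen can be compared so far, both with the rest of the core held constant. On these data alone, how a carboxylic acid, an amine or a longer alkyl chain at this position would read in this assay remains open.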